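Phenoxy to phenylsulfanyl swap: compound 2 to compound 3

The compounds below may be only part of what the source reports. "The series", "measured", "known", "first", "only" and "open" are said of these compounds alone.

Compound 1 `Nc1cc(N)c2nc(-c3ccccc3)c(Sc3ccc(Cl)c(Cl)c3)nc2c1`: in a functional assay on A549 cells (Homo sapiens) for inhibition, read by sulforhodamine B assay, with a stated time of 48 h (a lower number here means that less compound is tolerated, a higher number that more compound is tolerated), compound 1 gives only a limit, < 100000 nM.
Compound 2 `Nc1cc(N)c2nc(-c3ccccc3)c(Oc3ccc(F)cc3)nc2c1`: in this assay compound 2 gives 89100 nM.

Among the compounds with values here, compound 2 holds the only number in this assay; the one other value is a limit. The step that the limit leaves unreadable from compound 1 to compound 2 therefore cannot be read, because the limit of < 100000 nM in this assay, at which 1 of the 2 values shown sits, hides its size. Compound 3 `Nc1cc(N)c2nc(-c3ccccc3)c(Sc3ccc(F)cc3)nc2c1` differs from compound 2 by (4-fluorophenyl)sulfanyl in place of 4-fluorophenoxy on an aromatic carbon. Within the data shown here, no measured step bears on this change: the single step in the set is the unreadable one already named, so nothing shows how the linker atom moves the read-out. With no evidence for a shift in either direction, the step of a 1.1-fold lower number from compound 2 to compound 3 (0.05 log units; within the scatter) is expected to stay within the scatter. Compound 3 is estimated at 80000 nM in this assay, with a range from 30000 nM to 150000 nM.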

Compound 3, concentration lethal to 50% of the cells: 70800 nM
For compound 3 the middle estimate is 1.1-fold (0.05 log units) above the measured one, and the stated range covers the measured number.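

In this assay, within the data shown here, the first readable step at this position, on the aromatic carbon next to the ring nitrogen, is (4-fluorophenyl)sulfanyl in place of 4-fluorophenoxy, with a 1.3-fold lower number from compound 2 to compound 3 (0.10 log units; within the scatter). With the 4-fluorophenyl group held constant, the exchange of the linking oxygen for sulfur gives no difference that can be told from the scatter, so compound 2 and compound 3 stand as equivalent here. Both steps from compound 1 cannot be read because compound 1 carries only a limit: the limit of < 100000 nM in this assay, at which 1 of the 3 values shown sits.

Going by these compounds, the effect of 3,4-dichlorophenyl against 4-fluorophenyl on the sulfur therefore stays open. Also open, on these data alone, is how the read-out responds at this position to an amine linker in place of the sulfur or oxygen, or to a longer chain such as benzyloxy.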